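Swapping the triazole substituent in a gastric cancer cell series

A few compounds are considered here, and "the series" means these few. Any claim that something is new, unique, unknown or untested is made for them only; others in the source may bear on it.

Compound 1 `CC(C)n1ncc2c(C(=O)NCc3cn(-c4ccc(F)cc4)nn3)cccc21`: > 40000 nM, a limit of the assay rather than a number.
Compound 2 `Cc1ccccc1-n1cc(CNC(=O)c2cccc3c2cnn3C(C)C)nn1`: > 40000 nM, likewise a limit.
Compound 3 `CC(C)n1ncc2c(C(=O)NCc3cn(Cc4ccc(C(F)(F)F)cc4)nn3)cccc21`: > 40000 nM, likewise a limit.

All three values sit at the limit of > 40000 nM in this assay, at which 3 of the 3 values shown sit, in a functional assay on MGC-803 cells (Homo sapiens) for inhibition, read by MTT assay, with a stated time of 72 h (on this read-out lower numbers stand for stronger inhibition and higher numbers for weaker inhibition), so compound 1 stands nowhere that can be placed on a scale; it is simply not measurably active here. Compound 4 `COc1ccc(Cn2cc(CNC(=O)c3cccc4c3cnn4C(C)C)nn2)cc1` differs from compound 1 by 4-methoxybenzyl in place of 4-fluorophenyl on an aromatic nitrogen. For the measured compounds named here, the one comparable step, a step that the two limits leave unreadable from compound 1 to compound 2, cannot be read because both ends are limits, and compound 3, which also carries a benzyl group on that nitrogen, gives only a limit too. No step beyond the scatter is therefore expected in this assay; the estimated step that the limit leaves unreadable from compound 1 to compound 4 reflects this. Compound 4 is expected to give about 60000 nM, in the range 20000 nM to 200000 nM, most likely again reported only as a limit.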

Compound 4, half-maximal inhibitory concentration: > 40000 nM
Compound 4: a limit, no number; the forecaster's own chance of this, stated with the estimate: 85%; the middle value does not contradict the limit.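

Compound 4 gives a limit rather than a number, as do compound 1, compound 2 and compound 3, so no step among them can be read: the limit of > 40000 nM in this assay, at which 4 of the 4 values shown sit.

As far as these compounds go, whether any group on that aromatic nitrogen gives a measurable value stays open.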